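Phenylsulfanyl in place of phenyl on a pyrimidine ester

The source may hold more compounds than are shown below. What is called first, only, known or untested is meant among the compounds shown, and "the series" means these compounds.

Compound 1 `CCOC(=O)c1cnc(-c2ccccc2)nc1NN1C(=O)C=C(C)C1=O` is the reference point of this short series. In a functional assay on Jurkat cells for inhibition of nuclear factor NF-kappa-B complex (Homo sapiens) (on this read-out higher numbers stand for weaker inhibition and lower numbers for stronger inhibition), compound 1 gives 100 nM, the lowest of the two numbers recorded. For the measured compounds named here, its only measured neighbour is compound 2 `CCOC(=O)c1cnc(-c2cccc(OC)c2)nc1NN1C(=O)C=C(C)C1=O`, which in this assay gives 5000 nM; the single measured step, a 50-fold higher number from compound 1 to compound 2 (1.70 log units; beyond the scatter), shows how strongly this read-out responds to a change on the aryl group attached to the shared core.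

Compound 3 `CCOC(=O)c1cnc(Sc2ccccc2)nc1NN1C(=O)C=C(C)C1=O` has not been measured. Compared with compound 1 it carries phenylsulfanyl in place of phenyl on an aromatic carbon.

Going by the values given here, no measured step bears directly on this change: the only step recorded concerns a substituent added to the phenyl ring, not the replacement of the phenyl itself by phenylsulfanyl. Among the compounds with values here, the one step that exists was large, so the region around this aryl group appears sensitive, and the expectation is a weaker inhibition for compound 3, of modest size but with wide uncertainty. For compound 3 the estimated step is a 4.0-fold higher number from compound 1 to compound 3 (0.60 log units; beyond the scatter). Compound 3 is therefore expected to give about 400 nM, in a range from 100 nM to 3000 nM.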

Compound 3, half-maximal inhibitory concentration: 1000 nM
Compound 3: middle estimate off by 2.5-fold (0.40 log units), on the low side; the measured number falls inside the stated range.
By their numbers in this assay, from the lowest: compound 1; then compound 3; then compound 2.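

Replacing the phenyl itself at this carbon, between two ring nitrogen atoms, also moves the read-out in this assay, with a 10-fold higher number from compound 1 to compound 3 (1.00 log units; beyond the scatter), so the sensitivity seen earlier is not confined to a substituent added to the phenyl ring. The change to phenylsulfanyl is nevertheless less costly than the methoxy-bearing aryl group, as a 5.0-fold lower number from compound 2 to compound 3 (0.70 log units; beyond the scatter) shows, which places compound 3 in the middle of the three and leaves the plain phenyl of compound 1 with the lowest number. No supporting measurement is available to explain either step, so the data record the size of these changes but not their origin.

The compounds shown leave open whether a phenoxy group, with oxygen as the link, or a benzyl group, with a carbon as the link, would behave more like phenylsulfanyl or like phenyl. They also leave open whether a methoxy group on the phenylsulfanyl ring would raise the number as it does on phenyl, and whether a smaller group at this carbon, such as an amine, would improve on the value of compound 1.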